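Chlorine on a Phenyl Ring: a Small Expected Step

The compounds below may be only part of what the source reports. "The series", "measured", "known", "first", "only" and "open" are said of these compounds alone.

Compound 1 `Cc1nc(-c2ccc(Cl)cc2)sc1C(=O)CSc1nc(-c2ccc(Cl)c(Cl)c2)c(C#N)c(=O)[nH]1`, compound 2 `Cc1nc(-c2ccccc2)sc1C(=O)CSc1nc(-c2ccc(Cl)c(Cl)c2)c(C#N)c(=O)[nH]1` and compound 3 `COc1ccc(-c2nc(C)c(C(=O)CSc3nc(-c4ccccc4)c(C#N)c(=O)[nH]3)s2)cc1` have been measured; compound 4 `COc1ccc(-c2nc(C)c(C(=O)CSc3nc(-c4cccc(Cl)c4)c(C#N)c(=O)[nH]3)s2)cc1` has not. In a functional assay on U-87MG ATCC cells for antiproliferative activity against U-87 MG (Homo sapiens), read by MTT assay, with a stated time of 48 h, tested at 10 uM (a lower number here means a stronger effect, a higher number a weaker effect of the compound at the concentration tested), compound 1 gives 97.1%, compound 2 gives 92.5% and compound 3 gives 90.9%. The three numbers lie close together, and every difference among them is within the scatter, so the three measured compounds cannot be told apart at the tested concentration.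

Compound 2 and compound 1 differ in one place: chloro in place of hydrogen on an aromatic carbon. The measured result of that change is a number 4.6 percentage points higher from compound 2 to compound 1 (within the scatter). The difference between the core of compound 2 and the core of compound 3 is not broken down here.

Compound 4 is related to compound 3 by chloro in place of hydrogen on an aromatic carbon. For the measured compounds named here, this is the same kind of change as the one from compound 2 to compound 1, but not the same: in compound 1 the chloro stands para to a large group, in compound 4 it stands meta to a large group. Because a number 4.6 percentage points higher from compound 2 to compound 1 (within the scatter) stayed within the scatter, a similarly small step is expected here, a number 1.1 percentage points higher from compound 3 to compound 4 (within the scatter), resting on compound 3 at 90.9%. Compound 4 is therefore estimated at 92% in this assay, with a range from 82% to 101%. Going by the values given here, only a single earlier instance of this kind of change supports the expectation, and it comes from a different core.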

Compound 4, a percentage reported as activity, at one concentration (the size of the read-out at that concentration, not a potency): 90.6%
Estimate against measurement, compound 4: 1.4 percentage points above, within the range that was stated.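

In this assay, the change from phenyl to 3-chlorophenyl amounts to a number 0.3 percentage points lower from compound 3 to compound 4 (within the scatter). Set beside the earlier instance of this change, on a different core, the new step gives no sign that the core alters what the chloro does: the same change on two cores in this assay, a number 4.6 percentage points higher (within the scatter) from compound 2 to compound 1 and a number 0.3 percentage points lower (within the scatter) from compound 3 to compound 4, 4.9 percentage points apart, within the scatter of two such steps This shows only that the change left the read-out within the scatter in both pairs; it does not show that a measurable effect of chloro carries from one core to another, since neither pair has such an effect to carry, and two pairs at a single concentration are a thin basis, with the chloro entering a different ring in each.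

The compounds shown leave open whether any substituent on these aromatic rings can move the read-out clearly at all, for instance an amine or a carboxylic acid in place of the chloro. They also leave open whether a larger change elsewhere, such as a longer chain in place of the methyl group on the shared core, or the replacement of the nitrile, would separate compounds that cannot be told apart here.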